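Series notes: oxime ether pyrazoles, halogen swap on the aryl group

The source may hold more compounds than are shown below. What is called first, only, known or untested is meant among the compounds shown, and "the series" means these compounds.

Measured so far:
compound 1 `Cc1nn(C)c(Oc2ccc(OC(F)(F)F)cc2)c1/C=N\OCc1c(Cl)c(-c2ccc(F)cc2)nn1C` — 2310 nM
compound 2 `Cc1ccc(Oc2c(/C=N\OCc3c(Cl)c(-c4ccc(Cl)cc4)nn3C)c(C)nn2C)cc1` — 2850 nM

Both compounds were read in a functional assay on HCT-116 cells (Homo sapiens) for antiproliferative activity, read by MTT assay, with a stated time of 72 h; a higher number here means a weaker inhibitor, a lower number a stronger inhibitor. Compound 1 gives the lower of the two numbers, 2310 nM, but compound 2 with 2850 nM sits within the scatter of it, so the two cannot be ranked against each other.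

Compound 3 `Cc1nn(C)c(Oc2ccc(OC(F)(F)F)cc2)c1/C=N\OCc1c(Cl)c(-c2ccc(Cl)cc2)nn1C` is not yet measured. It differs from compound 1 in a single place: chloro in place of fluoro on an aromatic carbon. The rest of the shared core, the oxime ether link and the aryl ether on the other side are unchanged.

Within the data shown here, no step between measured compounds covers this exchange directly. What the two numbers show is that compound 2, which already carries the 4-chlorophenyl, and compound 1 with the 4-fluorophenyl lie within the scatter of each other, even though they also differ elsewhere. The expectation for this assay is therefore no step beyond the scatter, in either direction.

For compound 3 the estimated value in this assay is 2500 nM, with a range from 1200 nM to 5200 nM, which means an expected step of a 1.1-fold higher number from compound 1 to compound 3 (0.03 log units; within the scatter).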

Compound 3, half-maximal inhibitory concentration: 3020 nM
For compound 3 the middle estimate is 1.2-fold (0.08 log units) below the measured one; low and high end bracket the measured number.
By their numbers in this assay, from the lowest: compounds 1, 2 and 3 (each within the scatter of the next).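

In this assay the exchange of 4-fluorophenyl for 4-chlorophenyl now has a direct reading with everything else held fixed, a 1.3-fold higher number from compound 1 to compound 3 (0.12 log units; within the scatter), so fluoro and chloro cannot be told apart at this place on the six-membered aromatic ring. The aryl ether side also has its first direct reading, with the 4-chlorophenyl held fixed: trifluoromethoxy in place of methyl on an aromatic carbon gives a 1.1-fold higher number from compound 2 to compound 3 (0.03 log units; within the scatter), and these two groups cannot be told apart in these compounds either. No measurement at hand bears on why neither exchange moves the number beyond the scatter.

Both exchanges are single readings, and every step among these compounds stays within the scatter, so the series does not yet show any group at either place that shifts the number. As far as these compounds go, it remains open whether an amine or a carboxylic acid in place of the halogen on the phenyl ring, or a longer alkoxy chain in place of trifluoromethoxy, would give a step beyond the scatter.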